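Methylpiperazinyl replacement on the shared core

A few compounds are considered here, and "the series" means these few. Any claim that something is new, unique, unknown or untested is made for them only; others in the source may bear on it.

Measured compounds:
compound 1 `CN(C)CCCNc1nc(NCc2ccc(NC(=O)c3ccc(F)cc3)cc2)c2ccccc2n1` — 14000 nM
compound 2 `CNc1nc(NCc2ccc(C(=O)NC3CCN(Cc4ccc(F)cc4)CC3)cc2)c2cc(C)ccc2n1` — 1300 nM
compound 3 `C=CCNc1nc(NCc2ccc(C(=O)Nc3ccc(F)cc3)cc2)c2cc(C)ccc2n1` — 10000 nM

In a functional assay on SW480 cells (Homo sapiens) for inhibition, read by luminescence and resazurin assay, with a stated time of 3 days (on this read-out higher numbers stand for weaker inhibition and lower numbers for stronger inhibition), compound 1 stands at the highest of the three numbers. Compound 3 sits within the scatter of compound 1, so no order between the two can be stated. Compound 2 lies beyond the scatter at a lower number than compound 1.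

Compound 4 `CN1CCN(c2nc(NCc3ccc(NC(=O)c4ccc(F)cc4)cc3)c3ccccc3n2)CC1` has not been measured. It differs from compound 1 by 4-methylpiperazin-1-yl in place of (3-(dimethylamino)propyl)amino on an aromatic carbon. Within the data shown here, no pair of measured compounds covers this change, so nothing on file shows its size or direction. The expectation is that the step of a 1.3-fold lower number from compound 1 to compound 4 (0.10 log units; within the scatter) stays within the scatter, with no direction favoured. Compound 4 is therefore estimated at 11000 nM, with a range from 3500 nM to 35000 nM.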

Compound 4, half-maximal inhibitory concentration: 2500 nM
Compound 4: the middle estimate sits 4.4-fold (0.64 log units) above what was measured; the whole stated range lies above it.
By their numbers in this assay, from the lowest: compounds 2 and 4 (each within the scatter of the next); then compounds 3 and 1 (each within the scatter of the next).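

Among these compounds, the step of a 5.6-fold lower number from compound 1 to compound 4 (0.75 log units; beyond the scatter) in this assay is the first reading at this position, on the aromatic carbon between two ring nitrogen atoms, and it shows that the substituent there can move the number beyond the scatter. The heavy-atom count stays the same, while the ring replaces the open chain and the hydrogen-bond donor count falls to 0. Nothing on file accounts for this step.

On these data alone, whether the ring or the lost donor matters remains open. Morpholine or unsubstituted piperazine at this position would help separate the two.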